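The compounds below may be only part of what the source reports. "The series", "measured", "known", "first", "only" and "open" are said of these compounds alone.

Measured in a functional assay on HeLa cells (Homo sapiens) for cytotoxicity, read by MTT assay, with a stated time of 24 h; a higher number here means a weaker inhibitor, a lower number a stronger inhibitor:

- compound 1 `COc1ccc(/C=C2\CN(C)C/C(=C\c3ccccc3F)C2=O)cc1`: 23500 nM
- compound 2 `CN1C/C(=C\c2ccc(C(F)(F)F)cc2)C(=O)/C(=C/c2ccccc2F)C1`: 6560 nM
- compound 3 `CN1C/C(=C\c2ccc(C#N)cc2)C(=O)/C(=C/c2ccccc2F)C1`: 1340 nM

Compound 3 stands lowest of these three, and so is the strongest inhibitor among them. Compound 2 lies closest to it, and compound 1 lies furthest away.

The next compound, compound 4 `CN1C/C(=C\c2ccc(F)cc2)C(=O)/C(=C/c2ccc(C#N)cc2)C1`, has the same atoms as compound 3 joined differently. It carries 4-fluorophenyl in place of 2-fluorophenyl on a double-bonded chain carbon bound to a double-bonded ring carbon.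

Going by the values given here, all three measured compounds carry the 2-fluorophenyl, so no measured step moves that fluorine and none bears directly on this change. The steps offer only an indirect gauge of how far a single exchange on an aromatic carbon can move the number. They are a 3.6-fold lower number from compound 1 to compound 2 (0.55 log units; beyond the scatter), a 4.9-fold lower number from compound 2 to compound 3 (0.69 log units; beyond the scatter) and an 18-fold lower number from compound 1 to compound 3 (1.24 log units; beyond the scatter). Those exchanges replace one group with a different group, whereas here the same group changes place. A smaller step is therefore expected, probably none beyond the scatter, and the data suggest no direction. The expected step is a 1.1-fold higher number from compound 3 to compound 4 (0.05 log units; within the scatter). For compound 4 the estimated value is 1500 nM, with an expected range from 500 nM to 4500 nM.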

Compound 4, half-maximal inhibitory concentration: 10200 nM
The estimate for compound 4 lay 6.8-fold (0.83 log units) below the measured number; measured number above the stated range.
By their numbers in this assay, from the lowest: compound 3; then compounds 2 and 4 (each within the scatter of the next); then compound 1.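

Moving the fluorine alone, with the atoms of the molecule unchanged, gives in this assay a 7.6-fold higher number from compound 3 to compound 4 (0.88 log units; beyond the scatter), and this step lies beyond the scatter. The earlier compounds shown here all carried 2-fluorophenyl and differed only in the group exchanged on the other aromatic ring, so they could not show that the number also answers to where the fluorine stands on the phenyl on a double-bonded chain carbon bound to a double-bonded ring carbon; here 2-fluorophenyl goes with the lower number, though this rests on a single pair, with the nitrile-bearing ring held constant. No measurement available here accounts for the size or direction of this step.

From the compounds shown here alone, whether 2-fluorophenyl keeps this advantage when the other aromatic ring carries methoxy or trifluoromethyl in place of the nitrile remains open, since the pair is seen with the nitrile only. The compounds shown also leave open how a plain phenyl or a chlorophenyl at this place would compare with 2-fluorophenyl and 4-fluorophenyl.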